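From 4-Fluorophenyl to (Aminoamino)methyl at the Assay Limit

This account rests on a few compounds, and the source may have more. Where it says the series, first, only, none or still open, it means among the compounds named here.

In a functional assay on K562 cells (Homo sapiens) for inhibition (on this read-out lower numbers stand for stronger inhibition of growth and higher numbers for weaker inhibition of growth), compound 1 (`Nc1nn2c(O)cc(-c3cc([N+](=O)[O-])c(Cl)cc3Cl)nc2c1[N+](=O)[O-]`) gives > 50 ug/mL as a limit of the assay, not a number. Compound 2 (`Nc1nn2c(O)cc(-c3ccc(F)cc3)nc2c1[N+](=O)[O-]`) gives > 50 ug/mL in this assay, and this too is only a limit. Compound 2 therefore has no exact value, and both measured compounds sit at the same limit (the limit of > 50 ug/mL in this assay, at which 2 of the 2 values shown sit). Compound 3 (`NNCc1cc(O)n2nc(N)c([N+](=O)[O-])c2n1`) keeps the shared core but carries (aminoamino)methyl in place of 4-fluorophenyl on an aromatic carbon. Within the data shown here, no measured step shows what such a change does. With compound 2 reported only as > 50 ug/mL as a limit, no change beyond the scatter is expected in this assay, in either direction. The estimated step that the limit leaves unreadable from compound 2 to compound 3 is correspondingly small. For compound 3 the expected value is 60 ug/mL with an estimated range from 25 ug/mL to 120 ug/mL as its span.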

Compound 3, concentration for 50% growth inhibition: 26.5 ug/mL
Compound 3: middle estimate off by 2.3-fold (0.35 log units), on the high side; low and high end bracket the measured number.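

Among these compounds, with (aminoamino)methyl on this aromatic carbon next to the ring nitrogen, the shared core gives a measurable growth-inhibition value in this assay for the first time, whereas the aryl groups of the earlier compounds gave none. The change to the smaller, ring-free group produces an at least 1.8-fold lower number from compound 2 to compound 3 (0.27 log units; that floor lies within the scatter), so the step has a floor but no exact size, and that floor alone does not establish a real gain. Compound 3 is the only compound here with a number, and the others remain at a limit: the limit of > 50 ug/mL in this assay, at which 2 of the 3 values shown sit.

Going by these compounds, how far the true step extends beyond its floor stays unknown, as compound 2 has no exact value. On these data alone, it also remains open whether a simple amine, a methyl group or a longer chain ending in an amine would give a value like that of compound 3.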